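This account rests on a few compounds, and the source may have more. Where it says the series, first, only, none or still open, it means among the compounds named here.

In a functional assay on HepG2 cells (Homo sapiens) for cytotoxicity, read by colorimetric assay and neutral red uptake, with a stated time of 72 h (a higher number here means a weaker inhibitor, a lower number a stronger inhibitor), the measured compounds are:
compound 1 `CO[C@@H](C(=O)N[C@@H]1CC[C@H](O)CNC1=O)[C@H](O)[C@@H](O)[C@H](O)/C=C/C(C)(C)C` gives 138000 nM.
compound 2 `CO[C@@H](C(=O)N[C@H]1CC[C@@H](O)CNC1=O)[C@H](O)[C@@H](O)[C@H](O)/C=C/C(C)(C)C` gives only a limit of the assay, > 150000 nM.
compound 3 `CO[C@@H](C(=O)N[C@H]1CCCCNC1=O)[C@H](O)[C@@H](O)[C@H](O)/C=C/C(C)(C)C` gives 21100 nM.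

Compound 3 thus stands at the lowest of the two numbers in this assay; the step of a 6.5-fold lower number from compound 1 to compound 3 (0.82 log units; beyond the scatter) separates it from compound 1, and the step from compound 2 is an at least 7.1-fold lower number from compound 2 to compound 3 (0.85 log units; beyond the scatter).

Compound 4 `CO[C@@H](C(=O)N[C@@H]1CC[C@@H](O)CNC1=O)[C@H](O)[C@@H](O)[C@H](O)/C=C/C(C)(C)C` is compound 3 with 6-hydroxy-2-oxoazepan-3-yl in place of 2-oxoazepan-3-yl on an amide-type nitrogen. Both measured steps that bear on this, a 6.5-fold lower number from compound 1 to compound 3 (0.82 log units; beyond the scatter) and an at least 7.1-fold lower number from compound 2 to compound 3 (0.85 log units; beyond the scatter), removed the same hydroxy from the ring and lowered the number by a modest amount. Compound 4 restores that hydroxy in a configuration as drawn that matches neither compound 1 nor compound 2, so in this assay a step of similar size in the opposite direction, a higher number, is expected. Compound 4 is therefore estimated at 130000 nM (range 50000 nM to 300000 nM), an expected step of a 6.2-fold higher number from compound 3 to compound 4 (0.79 log units; beyond the scatter).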

Compound 4, half-maximal inhibitory concentration: 21300 nM
The estimate for compound 4 lay 6.1-fold (0.79 log units) above the measured number; the measured number lies below the stated range.
By their numbers in this assay, from the lowest: compounds 3 and 4 (each within the scatter of the next); then compound 1. At a limit, above all of these: compound 2.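

In this assay, the hydroxy of 6-hydroxy-2-oxoazepan-3-yl does not by itself set the number, as a 1.0-fold higher number from compound 3 to compound 4 (0.00 log units; within the scatter) shows. What counts is how it is combined with configuration, since a change at one saturated ring carbon gives a 6.5-fold lower number from compound 1 to compound 4 (0.81 log units; beyond the scatter), and the gap lies in configuration alone: the fact that compounds 1 and 4 differ only in the configuration as drawn Compound 2 gives only a limit of the assay, and an at least 7.0-fold lower number from compound 2 to compound 4 (0.84 log units; beyond the scatter) also comes from a change at one saturated ring carbon: the fact that compounds 2 and 4 differ only in the configuration as drawn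

The compounds shown leave open whether an amine or a carboxylic acid in place of this hydroxy would depend on configuration in the same way.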